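This account rests on a few compounds, and the source may have more. Where it says the series, first, only, none or still open, it means among the compounds named here.

Two related compounds have been measured so far. In a functional assay on MCF7 cells (Homo sapiens) for cytotoxicity, read by CellTiter-Glo, with a stated time of 5 days (on this read-out higher numbers stand for weaker inhibition and lower numbers for stronger inhibition), compound 1 (`CCC/C(=C(/c1ccc(/C=C/C(=O)O)cc1)c1ccc2[nH]ncc2c1)c1ccccc1`) gives 11 nM while compound 2 (`CC/C(=C(/c1ccc(/C=C/C(=O)O)cc1)c1cnc2[nH]ncc2c1)c1ccccc1`) gives 302 nM as the higher of the two numbers, a gap well beyond the scatter of repeated measurements. Compound 2 is therefore the weaker inhibitor of this pair. Compound 3 (`CC/C(=C(/c1ccc(/C=C/C(=O)O)cc1)c1ccc2[nH]nc(F)c2c1)c1ccccc1`) departs from compound 2 on a double-bonded chain carbon bound to an aromatic carbon and a double-bonded chain carbon, and the change is a group of 10 heavy atoms (7 carbon, 2 nitrogen, 1 fluorine; one five-membered aromatic ring with 2 hetero atoms, one six-membered aromatic ring of carbon only) in place of a group of 9 heavy atoms (6 carbon, 3 nitrogen; one five-membered aromatic ring with 2 hetero atoms, one six-membered aromatic ring with 1 hetero atom), on a double-bonded chain carbon bound to an aromatic carbon and a double-bonded chain carbon in full. The group that enters is 3-fluoro-1H-indazol-5-yl, with a six-membered aromatic ring of carbon only. Among the measured compounds shown here, no step between measured compounds that differ in one place is available, and no measured compound carries the fluorine, so the expectation is uncertain. Compound 1, with its value of 11 nM on this read-out, also has a six-membered aromatic ring of carbon only at this place, so a move toward stronger inhibition, beyond the scatter, is expected. The expected move is a 10-fold lower number from compound 2 to compound 3 (1.00 log units; beyond the scatter) as a rough estimate. For compound 3 the estimated value is 30 nM with an expected range from 7 nM to 120 nM in this assay as measured.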

Compound 3, half-maximal inhibitory concentration: 5 nM
For compound 3 the middle estimate is 6.0-fold (0.78 log units) above the measured one; the whole stated range lies above it.
By their numbers in this assay, from the lowest: compound 3; then compound 1; then compound 2.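

Replacing the group with a nitrogen in its six-membered aromatic ring by 3-fluoro-1H-indazol-5-yl gives a 60-fold lower number from compound 2 to compound 3 (1.78 log units; beyond the scatter) in this assay, a large step and the first that can be read at a single place in this series. It shows that the read-out responds strongly to the group on the double-bonded chain carbon bound to an aromatic carbon and a double-bonded chain carbon, even though the five-membered aromatic ring with 2 hetero atoms is present on both sides of the step. The step combines two changes, a six-membered aromatic ring of carbon only and the entry of a fluorine, and no information is available that would explain its size.

What the compounds leave open is how much of the step belongs to the fluorine and how much to the carbon-only ring, and compound 1 cannot settle this, as it differs from compound 3 in more than one place. From the compounds shown here alone, it also remains open how a chlorine, a methyl or a nitrile in place of the fluorine would read in this assay on the same core.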